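A few compounds are considered here, and "the series" means these few. Any claim that something is new, unique, unknown or untested is made for them only; others in the source may bear on it.

Measured so far:
- compound 1, `N=C(S)CCCCn1nc(-c2ccccc2)ccc1=O`: > 100 mg/kg
- compound 2, `CN(C)C(=S)CCCCCn1nc(-c2ccccc2)ccc1=O`: 100 mg/kg

Both values come from a functional assay on the whole organism (stomach) with Rattus norvegicus as the target; on this read-out higher numbers stand for an effect only at larger amounts of compound and lower numbers for an effect already at smaller amounts. For compound 1 the entry > 100 mg/kg is a limit of the assay and not a number. In this assay compound 2 gives 100 mg/kg. For the measured compounds named here, the single measured step, a number no higher from compound 1 to compound 2 (the limit leaves the size open), has a size that cannot be read, since the limit of > 100 mg/kg in this assay, at which 1 of the 2 values shown sits, leaves one end of it open. Compound 1 therefore stands only at the edge of what the assay could read.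

Compound 3, `Cc1ccc(=O)n(CCCCC(=N)S)n1`, has not yet been measured. It differs from compound 1 by methyl in place of phenyl on an aromatic carbon. Going by the values given here, no measured step concerns this change; the one step on record alters a different part of the molecule, and its size is unknown in any case. There is thus no measured basis for expecting a shift in either direction beyond the usual scatter of this assay.

Compound 3 is expected to give 100 mg/kg in this assay, with a range from 30 mg/kg to 300 mg/kg. The expected step of a number no higher from compound 1 to compound 3 (the limit leaves the size open) is estimated to be small, and a limit rather than a number is quite likely.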

Compound 3, dose for half-maximal effect: > 100 mg/kg
Compound 3: only a limit was reported; the forecaster's own chance of this, stated with the estimate: 55%; the middle value lies on the limit itself.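

In this assay compound 1 and compound 3 are each reported only as a limit and not as a number, so no step between them can be read: the limit of > 100 mg/kg in this assay, at which 2 of the 3 values shown sit.

On these data alone, whether methyl in place of phenyl changes the dose needed in either direction stays open, as does how far beyond the limit either compound lies.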